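The source may hold more compounds than are shown below. What is called first, only, known or untested is meant among the compounds shown, and "the series" means these compounds.

In a functional assay on HL-60 cells (Homo sapiens) for antiproliferative activity, with a stated time of 72 h (on this read-out higher numbers stand for weaker inhibition and lower numbers for stronger inhibition), three compounds sharing one core differ only in the aromatic group on a saturated chain carbon bound to a nitrogen on an aromatic ring. Compound 1 `OC[C@H]1O[C@@H](n2cnc3c(NCc4cccc(Br)c4)ncnc32)[C@H](O)[C@@H]1O` gives 8000 nM, compound 2 `OC[C@H]1O[C@@H](n2cnc3c(NCc4ccc(Cl)c(Cl)c4)ncnc32)[C@H](O)[C@@H]1O` gives 2000 nM, and compound 3 `COc1cc(CNc2ncnc3c2ncn3[C@@H]2O[C@H](CO)[C@@H](O)[C@H]2O)cc(OC)c1` gives 20200 nM, the highest number of the three. Compound 4 `OC[C@H]1O[C@@H](n2cnc3c(NCc4c(F)ccc(F)c4F)ncnc32)[C@H](O)[C@@H]1O` has 2,3,6-trifluorophenyl in place of 3,5-dimethoxyphenyl on a saturated chain carbon bound to a nitrogen on an aromatic ring. Going from a halogen-bearing phenyl to 3,5-dimethoxyphenyl raised the number both times, a 2.5-fold higher number from compound 1 to compound 3 (0.40 log units; beyond the scatter) and a 10-fold higher number from compound 2 to compound 3 (1.00 log units; beyond the scatter). Among the measured compounds shown here, the halogen-bearing groups also differ from each other, a 4.0-fold lower number from compound 1 to compound 2 (0.60 log units; beyond the scatter), and no fluorinated compound has been measured. A modest step to a lower number is therefore expected, a 3.4-fold lower number from compound 3 to compound 4 (0.53 log units; beyond the scatter). For compound 4 the estimated value is 6000 nM, with an expected range from 2000 nM to 20000 nM.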

Compound 4, half-maximal inhibitory concentration: 13000 nM
The estimate for compound 4 lay 2.2-fold (0.34 log units) below the measured number; low and high end bracket the measured number.
By their numbers in this assay, from the lowest: compound 2; then compounds 1, 4 and 3 (each within the scatter of the next, the first and the last beyond it).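

Halogens on this phenyl do not by themselves set a compound apart from the 3,5-dimethoxyphenyl compound, as the 2,3,6-trifluorophenyl group shows (a 1.6-fold lower number from compound 3 to compound 4 (0.19 log units; within the scatter)). That group also stays close to 3-bromophenyl (a 1.6-fold higher number from compound 1 to compound 4 (0.21 log units; within the scatter)), whereas 3,4-dichlorophenyl stands clearly apart (a 6.5-fold higher number from compound 2 to compound 4 (0.81 log units; beyond the scatter)), so compound 4 goes against the halogen trend suggested by compounds 1 and 2. No available evidence explains this spread. Still open, as far as these compounds go, is how the number would respond to an amine or a carboxylic acid on the phenyl ring, or to a longer chain carrying that ring.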